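Changing the aryl group on the core of compound 1

The source may report more compounds than this note shows. Statements on the series, on what has been measured and on what is new or still open speak of the compounds shown alone.

Measured compounds:
compound 1, `COc1cccc(CNCCCNc2ccnc3cc(-c4ccc(C(F)(F)F)cc4)ccc23)c1O`, 2210 nM
compound 2, `COc1ccc(-c2ccc3c(NCCCNCc4ccco4)ccnc3c2)cc1`, 6000 nM
compound 3, `FC(F)(F)c1ccc(-c2ccc3c(NCCCNCc4ccco4)ccnc3c2)cc1`, 3470 nM

All three were tested in an ADME assay on HepG2 cells (Homo sapiens) for cytotoxicity, read by luminescence, CellTiter-Glo and ATP content, with a stated time of 72 h; a lower number here means that less compound is needed, a higher number that more compound is needed for the effect. Compound 1 sits at the low end of the three numbers, but the step from it to compound 3, a 1.6-fold higher number from compound 1 to compound 3 (0.20 log units; within the scatter), is within the scatter, so the two are not distinguished; only the gap from compound 1 to compound 2 is beyond the scatter.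

Compound 4, `COc1cccc(CNCCCNc2ccnc3cc(Cc4ccc(F)cc4Cl)ccc23)c1O`, has not yet been measured. It differs from compound 1 at one place: 2-chloro-4-fluorobenzyl in place of 4-(trifluoromethyl)phenyl on an aromatic carbon. Within the data shown here, the one measured step that touches the same aryl group is the one from compound 2 to compound 3, a 1.7-fold lower number from compound 2 to compound 3 (0.24 log units; within the scatter), which stayed within the scatter. The step from compound 1 to compound 3 alters the other end of the molecule and says nothing about this position. Among the measured compounds shown here, the new change is larger than a single substituent swap, so the uncertainty is wider, but no measured step gives a direction.

Compound 4 is therefore expected to give about 2500 nM in this assay, with a range of 1000 nM to 6500 nM, a step of a 1.1-fold higher number from compound 1 to compound 4 (0.05 log units; within the scatter) that is expected to stay within the scatter.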

Compound 4, half-maximal effective concentration: 2350 nM
Compound 4: the middle estimate sits 1.1-fold (0.03 log units) above what was measured, within the range that was stated.
By their numbers in this assay, from the lowest: compounds 1, 4, 3 and 2 (each within the scatter of the next, the first and the last beyond it).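

Putting 2-chloro-4-fluorobenzyl in place of 4-(trifluoromethyl)phenyl on the aromatic carbon of the shared core gives a 1.1-fold higher number from compound 1 to compound 4 (0.03 log units; within the scatter) in this assay. The earlier step at this position only exchanged one substituent on a phenyl group, whereas this change replaces phenyl with benzyl and trifluoromethyl with chlorine and fluorine, and even so the two numbers cannot be told apart, so a change of this size at this position need not move the number beyond the scatter. No evidence is available that bears on the cause of this result.

The compounds shown leave open whether the benzyl form and the two halogens would each read the same on their own, since they enter together, and whether the same exchange would behave alike with the furan-2-yl end of compound 3 in place of the 2-hydroxy-3-methoxyphenyl end. They also leave open how a quite different group on this carbon, such as a morpholine, a carboxylic acid or a longer chain ending in an amine, would read in this assay.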